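The source may hold more compounds than are shown below. What is called first, only, known or untested is meant among the compounds shown, and "the series" means these compounds.

- Compound 1 `CCC(/C=C1\OC(=O)NC1=O)(CC)c1ccc(-c2ccc3cccc(F)c3c2)[nH]c1=O`: 32600 nM
- Compound 2 `CC(C)C(c1ccc(-c2ccc3cccc(F)c3c2)[nH]c1=O)C1NC(=O)NC1=O`: 10600 nM

Both numbers come from a physicochemical assay for solubility, in phosphate buffer, measured as kinetic solubility; on this read-out higher numbers stand for higher solubility and lower numbers for lower solubility. Of the two, compound 2 is the lower, at 10600 nM, and the gap to compound 1 lies beyond the scatter. Compound 3 `CC(C)C(/C=C1/C(=O)NC(=O)N1C)c1ccc(-c2ccc3cccc(F)c3c2)[nH]c1=O` differs from compound 2 in one place, on a saturated chain carbon bound to an aromatic carbon and a saturated chain carbon: a group of 9 heavy atoms (5 carbon, 2 nitrogen, 2 oxygen; one five-membered non-aromatic ring with 2 hetero atoms) in place of a group of 7 heavy atoms (3 carbon, 2 nitrogen, 2 oxygen; one five-membered non-aromatic ring with 2 hetero atoms), on a saturated chain carbon bound to an aromatic carbon and a saturated chain carbon. Going by the values given here, no measured pair shows this kind of change, so any forecast is loose. The expected step is a 1.4-fold higher number from compound 2 to compound 3 (0.15 log units; within the scatter), a slight rise that need not pass the scatter. For compound 3 the estimated value is 15000 nM, with an expected range of 5000 nM to 40000 nM.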

Compound 3, solubility: 34800 nM
Beside the measured number, compound 3's estimate is 2.3-fold (0.37 log units) below it; measured number inside the range.
By their numbers in this assay, from the lowest: compound 2; then compounds 1 and 3 (each within the scatter of the next).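

In this assay, putting the larger group on this saturated chain carbon in place of 2,5-dioxoimidazolidin-4-yl gives a 3.3-fold higher number from compound 2 to compound 3 (0.52 log units; beyond the scatter), so the number responds to what sits at this position. The change is not a single feature: the entering group has more heavy atoms, one more double bond outside aromatic rings and one hydrogen-bond donor fewer. Nothing here ties the rise to any one of these differences.

A single step cannot separate them. On these data alone, how an amine, a carboxylic acid or a longer chain on this carbon would compare remains open.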